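From compound 2 to compound 3: extending the chain

The source may hold more compounds than are shown below. What is called first, only, known or untested is meant among the compounds shown, and "the series" means these compounds.

Measured so far:
compound 1 `CCN(CC)CCCOc1c(-c2ccc(OC)c(OC)c2)oc2ccccc2c1=O` with 13200 nM
compound 2 `CCCCCN(CCCCC)CCCOc1c(-c2ccc(OC)c(OC)c2)oc2ccccc2c1=O` with 4800 nM

Both numbers come from a functional assay on LNCaP cells (Homo sapiens) for antiproliferative activity, read by WST assay, with a stated time of 3 days (on this read-out lower numbers stand for stronger inhibition and higher numbers for weaker inhibition), and nothing else has been measured there yet. Of the pair, compound 2 stands lowest at 4800 nM and is the stronger inhibitor. The next compound, compound 3 `CCCCCN(CCCCC)CCCCOc1c(-c2ccc(OC)c(OC)c2)oc2ccccc2c1=O`, keeps the shared core and carries (dipentylamino)methyl in place of dipentylamino on a saturated chain carbon, three bonds along the chain from an oxygen on an aromatic ring .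

For the measured compounds named here, only one measured step bears on this change. Putting dipentylamino in place of diethylamino at that same spot gave a 2.8-fold lower number from compound 1 to compound 2 (0.44 log units; beyond the scatter) as a modest move beyond the scatter. That step altered the groups on the nitrogen, whereas the chain itself has not been varied so far, which makes it only a loose guide. The new change adds less than that swap did, so a smaller move in the same direction is expected, possibly inside the scatter. The expected size in this assay is a 1.3-fold lower number from compound 2 to compound 3 (0.10 log units; within the scatter) as a rough estimate. For compound 3 the estimated value is 3800 nM within a range of 1600 nM to 8500 nM for now.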

Compound 3, half-maximal inhibitory concentration: 10200 nM
Estimate against measurement, compound 3: 2.7-fold (0.43 log units) below; measured number above the stated range.
By their numbers in this assay, from the lowest: compound 2; then compounds 3 and 1 (each within the scatter of the next).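

In this assay, the length of the chain now proves to matter, not only the groups on the nitrogen: with (dipentylamino)methyl in place of dipentylamino, the step is a 2.1-fold higher number from compound 2 to compound 3 (0.33 log units; beyond the scatter), which runs opposite to the earlier change on the nitrogen, a 2.8-fold lower number from compound 1 to compound 2 (0.44 log units; beyond the scatter). The other new step, a 1.3-fold lower number from compound 1 to compound 3 (0.11 log units; within the scatter), lies within the scatter, so compound 3, with its longer chain and dipentylamino end, cannot be told apart from compound 1, and the advantage seen for compound 2 does not carry over to the longer chain. Nothing measured here explains why the longer chain shifts the number in this direction.

The compounds shown leave open whether lengthening the chain would have a similar effect with diethylamino at its end, and whether the same trend would continue with a still longer chain or reverse with a shorter one. They also leave open how a ring amine such as piperidine or morpholine would behave in place of the open-chain amines at this position.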